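Cyclopropylamide to free acid: the cytotoxicity outlook

The compounds below may be only part of what the source reports. "The series", "measured", "known", "first", "only" and "open" are said of these compounds alone.

Three measured compounds share one core and differ only at the carbonyl end of the chain. In an ADME assay on S2 cells (Drosophila melanogaster) for cytotoxicity, read by MTT assay (a higher number here means that more compound is needed for the effect, a lower number that less compound is needed), compound 1 `CCOC(=O)/C=C/[C@H]1C[C@@H](O)[C@@H](O)C1` gives only a limit, > 350000 nM. Compound 2 `NC(=O)/C=C/[C@H]1C[C@@H](O)[C@@H](O)C1` also gives only a limit in this assay, > 250000 nM. Compound 3 `O=C(/C=C/[C@H]1C[C@@H](O)[C@@H](O)C1)NC1CC1` likewise gives only a limit in this assay, > 250000 nM. The steps a step that the two limits leave unreadable from compound 1 to compound 2, a step that the two limits leave unreadable from compound 1 to compound 3 and a step that the two limits leave unreadable from compound 2 to compound 3 stay unreadable because every value sits at the limit of > 250000 nM in this assay, at which 2 of the 3 values shown sit, or (the limit of > 350000 nM in this assay, at which 1 of the 3 values shown sits). Compound 4 `O=C(O)/C=C/[C@H]1C[C@@H](O)[C@@H](O)C1` differs from compound 3 by hydroxy in place of cyclopropylamino on a carbonyl carbon. With no readable step to build on, compound 4 is expected to remain at a limit as well, so a step that the limit leaves unreadable from compound 3 to compound 4 is expected to be of no measurable size. Compound 4 is estimated at 300000 nM in this assay, between 150000 nM and 1000000 nM.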

Compound 4, half-maximal effective concentration: > 350000 nM
Compound 4: no number, only a limit; the forecaster's own chance of this, stated with the estimate: 85%; middle value at least 1.1-fold (0.06 log units) away from the limit.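

Among the compounds shown here, compound 4 gives only a limit in this assay, as do compound 1, compound 2 and compound 3, so no step to compound 4 can be read. The compounds shown leave open whether changing the group on the carbonyl carbon alters cytotoxicity at all.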